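The source may hold more compounds than are shown below. What is called first, only, known or untested is meant among the compounds shown, and "the series" means these compounds.

Compound 3 `Cc1ccc2nc(N3CCCc4ccc(F)cc4C3)cc(NCCN3CCNCC3)c2c1` is one of two compounds that give a number in an ADME assay on HEp-2 cells (Homo sapiens) for cytotoxicity, read by CCK-8 assay, with a stated time of 5 days; a lower number here means that less compound is tolerated, a higher number that more compound is tolerated: compound 3 gives 40000 nM, and compound 2 `Cc1ccc2nc(N3CCCc4ccc(F)cc4C3)cc(NCC(C)(C)N)c2c1` gives 23000 nM, the step of a 1.7-fold higher number from compound 2 to compound 3 (0.24 log units; within the scatter) staying within the scatter. Compound 1 `Cc1ccc2nc(N3CCCc4ccc(F)cc4C3)cc(NCCN)c2c1` gives only a limit in this assay, > 3200 nM, so that the steps a step that the limit leaves unreadable from compound 1 to compound 2 and a step that the limit leaves unreadable from compound 1 to compound 3 cannot be read (the limit of > 3200 nM in this assay, at which 1 of the 3 values shown sits). Compound 4 `Cc1ccc2nc(N3CCCc4ccc(F)cc4C3)cc(NCCN3CCCCC3)c2c1` differs from compound 3 by piperidin-1-yl in place of piperazin-1-yl on a saturated chain carbon, two bonds along the chain from a nitrogen on an aromatic ring. Among the measured compounds shown here, the only readable step, that from compound 2 to compound 3, brought the piperazin-1-yl in and moved the number within the scatter; no measured step exchanges piperazin-1-yl for piperidin-1-yl. The expected step of a 1.3-fold lower number from compound 3 to compound 4 (0.12 log units; within the scatter) is therefore estimated to stay within the scatter. Compound 4 is expected to give about 30000 nM, in a range from 10000 nM to 90000 nM.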

Compound 4, half-maximal cytotoxic concentration: 22000 nM
The estimate for compound 4 lay 1.4-fold (0.13 log units) above the measured number; measured number inside the range.
By their numbers in this assay, from the lowest: compounds 4, 2 and 3 (each within the scatter of the next).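

In this assay, piperidin-1-yl, which has no hydrogen-bond donor, replaces piperazin-1-yl at this place and gives a 1.8-fold lower number from compound 3 to compound 4 (0.26 log units; within the scatter), so the ring's donor makes no readable difference here. The replacement of the 1-amino-1-methylethyl chain end gives a 1.0-fold lower number from compound 2 to compound 4 (0.02 log units; within the scatter), which also stays within the scatter. Compound 1 gives only a limit, so its step to compound 4 cannot be read, and neither can its other steps: the limit of > 3200 nM in this assay, at which 1 of the 4 values shown sits.

The compounds shown leave open whether morpholin-4-yl on this chain, or a longer chain carrying piperidin-1-yl, would also stay within the scatter.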